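A few compounds are considered here, and "the series" means these few. Any claim that something is new, unique, unknown or untested is made for them only; others in the source may bear on it.

Compounds 1, 2 and 3 were tested in a functional assay on MDA-MB-231 cells (Homo sapiens) for cytotoxicity, read by MTT assay, with a stated time of 24 h; on this read-out higher numbers stand for weaker inhibition and lower numbers for stronger inhibition. Compound 1 `O=C1/C(=C/c2ccccc2F)CN(Cc2cn(Cc3ccccc3F)nn2)C/C1=C\c1ccccc1F` carries a 2-fluorobenzyl group on its triazole, and in this assay compound 1 gives 16000 nM. Compound 2 `O=C1/C(=C/c2ccccc2F)CN(Cc2cn(Cc3ccccc3Cl)nn2)C/C1=C\c1ccccc1F` is its 2-chlorobenzyl counterpart, and in this assay compound 2 gives 16500 nM. The change between them is fluoro in place of chloro on an aromatic carbon, and it moved the read-out by a 1.0-fold lower number from compound 2 to compound 1 (0.01 log units; within the scatter).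

Compound 3 `COc1ccc(/C=C2\CN(Cc3cn(Cc4ccccc4Cl)nn3)C/C(=C\c3ccc(OC)cc3)C2=O)cc1` shares the 2-chlorobenzyl group of compound 2 but rests on a different core; the difference between the two cores is not broken down here. For compound 3 in this assay only a limit is reported, > 100000 nM, which is the limit of > 100000 nM in this assay, at which 1 of the 3 values shown sits, and not a measured number.

Compound 4 `COc1ccc(/C=C2\CN(Cc3cn(Cc4ccccc4F)nn3)C/C(=C\c3ccc(OC)cc3)C2=O)cc1` has not yet been measured. It differs from compound 3 by fluoro in place of chloro on an aromatic carbon, the same change that separates compound 2 from compound 1. Since that change gave a 1.0-fold lower number from compound 2 to compound 1 (0.01 log units; within the scatter) on the core shared by compounds 1 and 2, a step of similarly small size is expected here, a number no higher from compound 3 to compound 4 (the limit leaves the size open), with the difference that it starts from a limit rather than a number. Compound 4 is therefore expected to give about 100000 nM in this assay, with the estimate running from 50000 nM to 300000 nM, and it is likely that only a limit will again be reported.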

Compound 4, half-maximal inhibitory concentration: 67200 nM
Compound 4: middle estimate off by 1.5-fold (0.17 log units), on the high side, and the stated range covers the measured number.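

Carried to the core of compound 3 in this assay, fluoro in place of chloro on an aromatic carbon gave an at least 1.4-fold lower number from compound 3 to compound 4 (0.17 log units; that floor lies within the scatter), so on this second core the change is tied to a step whose full size cannot be read. Compound 3 gives > 100000 nM, which is a limit of the assay and not a number, so the step rests on a floor and not on two measured values. The result shows that the change can be carried to a second core without the number rising, and that on both cores the size that can be read stays within the scatter, but it does not show that the change has the same size on the two cores: the same change on two cores in this assay, a 1.0-fold lower number (0.01 log units; within the scatter) from compound 2 to compound 1 and an at least 1.4-fold lower number (0.17 log units; that floor lies within the scatter) from compound 3 to compound 4; the limit leaves it open whether they differ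

The compounds shown leave open how the read-out would respond to a group other than these two halogens at the same place on the benzyl ring, such as a nitrile, an amine or a carboxylic acid, and whether a longer chain in place of the benzyl link would alter it. They also leave open whether the step seen here would hold on any core beyond these two.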